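Substituents on the Amide Nitrogen and Paw Edema Inhibition

A few compounds are considered here, and "the series" means these few. Any claim that something is new, unique, unknown or untested is made for them only; others in the source may bear on it.

Compound 1, `NC(=O)c1nc(-c2ccccc2)n(-c2ccc(S(N)(=O)=O)cc2)n1`, gives 49% in a functional assay on the whole organism for inhibition, with Rattus norvegicus as the target, read by paw edema, with stated times of 30 min and 4 h, at a dose of 0.28 mmol/kg by the oral route; a lower number here means less inhibition, a higher number more inhibition at the dose given (going by the name of the read-out).
Compound 2, `NS(=O)(=O)c1ccc(-n2nc(C(=O)NC3CCCCC3)nc2-c2ccccc2)cc1`, gives 53% in this assay.
Compound 3, `NNC(=O)c1nc(-c2ccccc2)n(-c2ccc(S(N)(=O)=O)cc2)n1`, gives 45% in this assay.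

Compound 3 carries the smallest of the three numbers, yet the steps of a number 4 percentage points lower from compound 1 to compound 3 (within the scatter) and a number 8 percentage points lower from compound 2 to compound 3 (within the scatter) both lie within the scatter, so no order among the three is established. Compound 4, `CC(C)NC(=O)c1nc(-c2ccccc2)n(-c2ccc(S(N)(=O)=O)cc2)n1`, differs from compound 3 by isopropyl in place of amino on an amide-type nitrogen. The related steps on the same nitrogen, a number 4 percentage points higher from compound 1 to compound 2 (within the scatter) and a number 8 percentage points lower from compound 2 to compound 3 (within the scatter), show that hydrogen, cyclohexyl and amino at this place give numbers within the scatter of one another. Compound 4 is therefore expected to stay close to its neighbours, with an estimated step of a number 5 percentage points higher from compound 3 to compound 4 (within the scatter). The estimate for compound 4 in this assay is 50%, ranging from 38% to 62%.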

Compound 4, a percentage reported as inhibition, in the whole organism at one dose (the size of the read-out at that dose, not a potency): 44%
Beside the measured number, compound 4's estimate is 6 percentage points above it; low and high end bracket the measured number.
By their numbers in this assay, from the lowest: compounds 4, 3, 1 and 2 (each within the scatter of the next).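

Isopropyl now joins hydrogen, amino and cyclohexyl on the amide-type nitrogen, and in this assay the new steps read a number 1 percentage points lower from compound 3 to compound 4 (within the scatter), a number 5 percentage points lower from compound 1 to compound 4 (within the scatter) and a number 9 percentage points lower from compound 2 to compound 4 (within the scatter). Trading amino for isopropyl removes a hydrogen-bond donor and acceptor from this place without a step beyond the scatter, and isopropyl and cyclohexyl do not separate either. Nothing available explains this result. As far as these compounds go, whether a carboxylic acid in place of the amide, or a longer chain ending in an amine on this nitrogen, would move the number beyond the scatter remains open.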